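The compounds below may be only part of what the source reports. "The series", "measured", "known", "first", "only" and "open" are said of these compounds alone.

Of the compounds shown here, three that share one core have been tested in a functional assay on HEK293 cells (Homo sapiens) for cytotoxicity; a higher number here means that more compound is tolerated, a lower number that less compound is tolerated. Compound 1 `COc1ccc([C@H]2CC(=O)N(Cc3cccc([N+](=O)[O-])c3)C2)cc1OC1CCCC1` gives > 10000 nM, which is a limit of the assay and not a number. Compound 2 `COc1ccc([C@H]2CC(=O)N(c3ccncc3)C2)cc1OC1CCCC1`, with pyridin-4-yl in place of 3-nitrobenzyl on the amide-type nitrogen, gives > 10000 nM, also a limit. Compound 3 `COc1ccc([C@H]2CC(=O)N(c3cccc([S+](C)[O-])c3)C2)cc1OC1CCCC1` gives > 10000 nM, again a limit. Compound 3 therefore stands with the other two, as this summary shows: the limit of > 10000 nM in this assay, at which 3 of the 3 values shown sit.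

Compound 4 `COc1ccc([C@H]2CC(=O)N(c3cccc(S(C)(=O)=O)c3)C2)cc1OC1CCCC1` differs from compound 3 in a single group: a group of 4 heavy atoms (1 carbon, 2 oxygen, 1 sulfur; no ring) in place of a group of 3 heavy atoms (1 carbon, 1 oxygen, 1 sulfur; no ring), on an aromatic carbon. The new methylsulfonyl group sits on an aromatic carbon, meta to a large group.

The measured steps that bear on this change all concern the group on the amide-type nitrogen: a step that the two limits leave unreadable from compound 1 to compound 2, a step that the two limits leave unreadable from compound 1 to compound 3 and a step that the two limits leave unreadable from compound 2 to compound 3. None of them has a readable size, so they offer no measured shift to carry over, and they only show three different groups at the same limit. No step beyond the usual scatter is expected in this assay, and no direction is expected either. The expected change is a step that the limit leaves unreadable from compound 3 to compound 4. Most likely the assay will report a limit again. For compound 4 the estimated value is 15000 nM, with an expected range from 9000 nM to 40000 nM.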

Compound 4, half-maximal cytotoxic concentration: > 10000 nM
Compound 4 ended at the assay's limit (the forecaster's own chance of this, stated with the estimate: 90%); the middle value is on the limit's open side.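

Compound 4 gives a limit and not a number in this assay, as do compound 1, compound 2 and compound 3, so none of the steps among these compounds can be read: the limit of > 10000 nM in this assay, at which 4 of the 4 values shown sit.

The compounds shown leave open what concentration of any of them is cytotoxic, and whether their different groups on the amide-type nitrogen differ in this respect.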